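This account rests on a few compounds, and the source may have more. Where it says the series, first, only, none or still open, it means among the compounds named here.

In a functional assay on HCT-116 cells (Homo sapiens) for inhibition, read by colorimetric assay and sulforhodamine B assay, with a stated time of 48 h (a higher number here means a weaker inhibitor of growth, a lower number a stronger inhibitor of growth), compound 1 `CCCCCCCCCCCC[C@@H](O)[C@H]1CC[C@H]([C@H](O)CCCCCCCCCCNC(=O)c2ccco2)O1` gives 7760 nM, compound 2 `CCCCCCCCCCCC[C@@H](O)[C@H]1CC[C@H]([C@H](O)CCCCCCCCCCNC(=O)c2cncs2)O1` gives 12900 nM and compound 3 `CCCCCCCCCCCC[C@@H](O)[C@H]1CC[C@H]([C@H](O)CCCCCCCCCCNC(=O)c2ccsc2)O1` gives 1290 nM. Compound 3 therefore has the lowest number of the three. Compound 4 `CCCCCCCCCCCC[C@@H](O)[C@H]1CC[C@H]([C@H](O)CCCCCCCCCCNC(=O)c2ccnn2C)O1` keeps the shared core and has 1-methyl-1H-pyrazol-5-yl in place of thiophen-3-yl on a carbonyl carbon. The nearest evidence is a 6.0-fold lower number from compound 1 to compound 3 (0.78 log units; beyond the scatter) and a 10-fold lower number from compound 2 to compound 3 (1.00 log units; beyond the scatter), both of which arrive at thiophen-3-yl. Read in reverse, they suggest that leaving it raises the number, although only these two cases exist. The remaining step, a 1.7-fold higher number from compound 1 to compound 2 (0.22 log units; within the scatter), shows no separation between furan-2-yl and 1,3-thiazol-5-yl. A rise of similar size is therefore expected in this assay, and the estimated change is a 5.8-fold higher number from compound 3 to compound 4 (0.76 log units; beyond the scatter). For compound 4 the estimate is 7500 nM, with an expected range of 2500 nM to 20000 nM.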

Compound 4, concentration for 50% growth inhibition: 10 nM
Estimate against measurement, compound 4: 750-fold (2.88 log units) above; the whole stated range lies above it.
By their numbers in this assay, from the lowest: compound 4; then compound 3; then compounds 1 and 2 (each within the scatter of the next).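

On the carbonyl carbon, 1-methyl-1H-pyrazol-5-yl stands apart from the three other rings in this assay (a 130-fold lower number from compound 3 to compound 4 (2.11 log units; beyond the scatter)), (a 780-fold lower number from compound 1 to compound 4 (2.89 log units; beyond the scatter)) and (a 1300-fold lower number from compound 2 to compound 4 (3.11 log units; beyond the scatter)). Going by these compounds alone, each of these steps is larger than any step among furan-2-yl, 1,3-thiazol-5-yl and thiophen-3-yl, so the ring on this carbonyl can move the number much further than the earlier compounds showed. Nothing available here accounts for the size of this step.

From the compounds shown here alone, whether it depends on the methyl or on the ring remains open. An unmethylated 1H-pyrazol-5-yl, a pyridine ring or a 1-ethyl-1H-pyrazol-5-yl at this place would begin to separate the two.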